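The compounds below may be only part of what the source reports. "The series", "measured", "known", "first", "only" and "open" are said of these compounds alone.

Measured compounds:
Compound 1, `COc1ccc(-n2cc(-c3ccc(OC)c(OC)c3)nn2)cc1`: > 100 nM
Compound 2, `COc1cc(-c2cn(-c3cc(OC)c(OC)c(OC)c3)nn2)cc(OC)c1OC`: > 10000 nM
Compound 3, `COc1ccc(-c2cn(-c3ccc(OC)cc3)nn2)cc1`: > 100 nM

In a functional assay on MDA-MB-231 cells (Homo sapiens) for cytotoxicity, read by MTT assay (on this read-out higher numbers stand for weaker inhibition and lower numbers for stronger inhibition), compound 1 gives > 100 nM, which is a limit of the assay and not a number. Compound 3 gives > 100 nM in this assay, likewise a limit. Compound 3 differs from compound 1 by hydrogen in place of methoxy on an aromatic carbon, and the step that the two limits leave unreadable from compound 1 to compound 3 cannot be read. Two of the three values sit at the limit of > 100 nM in this assay, at which 2 of the 3 values shown sit. Compound 2 gives > 10000 nM in this assay, again a limit, at the limit of > 10000 nM in this assay, at which 1 of the 3 values shown sits. How the core of compound 2 differs from that of compound 1 is not broken down here.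

Compound 4, `COc1cc(OC)cc(-c2cn(-c3cc(OC)c(OC)c(OC)c3)nn2)c1`, is not yet measured. It differs from compound 2 by hydrogen in place of methoxy on an aromatic carbon. This is the same kind of change as that from compound 1 to compound 3, not the same one: in compound 4 the place is ortho to two methoxy groups and para to a large group, whereas in compound 3 it is ortho to a methoxy group and meta to a large group. Among the compounds with values here, the one measured instance of this kind of change gives no readable size. The step from compound 2 to compound 4 is expected to be a step that the limit leaves unreadable from compound 2 to compound 4. Compound 4 is estimated at 15000 nM, between 3000 nM and 60000 nM, with a limit the likely outcome.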

Compound 4, half-maximal inhibitory concentration: > 10000 nM
Compound 4: only a limit was reported; the forecaster's own chance of this, stated with the estimate: 70%; the middle value does not contradict the limit.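

Within the data shown here, compound 2 and compound 4 are both reported only as limits, so the step between them cannot be read, and this result yields no new step. The compounds shown leave open how large the change from methoxy to hydrogen is, in this pair or in compound 1 and compound 3, and what any of the four actual values is.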